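The source may report more compounds than this note shows. Statements on the series, on what has been measured and on what is new or still open speak of the compounds shown alone.

In a functional assay on A549 cells (Homo sapiens) for cytotoxicity, read by MTT assay, with a stated time of 48 h (on this read-out higher numbers stand for weaker inhibition and lower numbers for stronger inhibition), compound 1 `COc1ccc(N/C=C\C(=O)c2nc(-c3ccc(F)cc3)n3ccccc23)cc1` gives 19200 nM. Compound 2 `O=C(/C=C\Nc1ccc2[nH]ccc2c1)c1nc(-c2ccc(C(F)(F)F)cc2)n2ccccc12`, which carries a trifluoromethyl-substituted aryl ring on the shared core and a 1H-indol-5-yl group on the amine nitrogen, gives 5190 nM in this assay. Compound 3 `O=C(/C=C\Nc1ccc(F)cc1)c1nc(-c2ccc(C(F)(F)F)cc2)n2ccccc12` returns only a limit in this assay, > 30000 nM, which is the limit of > 30000 nM in this assay, at which 1 of the 3 values shown sits. The change that leads there is 4-fluorophenyl in place of 1H-indol-5-yl on the amine nitrogen, and it gives an at least 5.7-fold higher number from compound 2 to compound 3 (0.76 log units; beyond the scatter), so compound 3 stands at the weak end of the three values shown, with no number of its own.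

Compound 4 `COc1ccc(N/C=C\C(=O)c2nc(-c3ccc(C(F)(F)F)cc3)n3ccccc23)cc1` differs from compound 3 in one place: methoxy in place of fluoro on an aromatic carbon. Going by the values given here, only one measured step bears on this position, and it shows that the group on the amine nitrogen can shift the number by a modest amount. Compound 1, which carries the same (4-methoxyphenyl)amino group but a 4-fluorophenyl ring on the core, gives a number just under the limit. Compound 4 is therefore expected to sit close to that limit, with the estimated step being an at least 1.2-fold lower number from compound 3 to compound 4 (0.07 log units; that floor lies within the scatter), and it may again return only a limit. The estimate for compound 4 in this assay is 25000 nM, within 10000 nM to 60000 nM.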

Compound 4, half-maximal inhibitory concentration: 21800 nM
Estimate against measurement, compound 4: 1.1-fold (0.06 log units) above, within the range that was stated.
By their numbers in this assay, from the lowest: compound 2; then compounds 1 and 4 (each within the scatter of the next). At a limit, above all of these: compound 3.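

Methoxy in place of fluoro on an aromatic carbon gives an at least 1.3-fold lower number from compound 3 to compound 4 (0.13 log units; that floor lies within the scatter) in this assay, so this change is seen only as a floor. Compound 3 holds only a limit, which leaves the true size of that step unknown: the limit of > 30000 nM in this assay, at which 1 of the 4 values shown sits.

Going by these compounds alone, what the earlier compounds did not show is how the two ends of the molecule compare when the (4-methoxyphenyl)amino group or the trifluoromethyl-substituted ring is held fixed: exchanging fluoro for trifluoromethyl gives a 1.1-fold higher number from compound 1 to compound 4 (0.06 log units; within the scatter), whereas exchanging the 1H-indol-5-yl group for the 4-methoxyphenyl group gives a 4.2-fold higher number from compound 2 to compound 4 (0.62 log units; beyond the scatter).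

The compounds shown leave open how a hydroxyl, a dimethylamino group or a chloro in the same place on the six-membered aromatic ring would read in this assay, and so whether any simple phenyl group can match the 1H-indol-5-yl group. As far as these compounds go, it is also open whether a nitrile or a methyl in place of trifluoromethyl on the aryl ring of the shared core would keep compound 4 within the scatter of its number.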